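A few compounds are considered here, and "the series" means these few. Any claim that something is new, unique, unknown or untested is made for them only; others in the source may bear on it.

Working notes on an ADME assay on microsomes from liver (Rattus norvegicus) for metabolic stability; a higher number here means that the compound lasts longer, a lower number that the compound disappears faster. For the measured compounds named here, compound 1 `CC(C)C(c1ccc(-c2ccc3cccc(F)c3c2)[nH]c1=O)C1NC(=O)NC1=O` gives 0.145 h, the only exact number so far. Compound 2 `CC(C)/C(=C1\C(=O)NC(=O)N1C)c1ccc(-c2ccc3cccc(F)c3c2)[nH]c1=O` is reported as > 3 h, which is a limit of the assay and not a number. Compound 1 therefore stands at the short-lived end of the two compounds.

Compound 3 `CC(C)C(CC1NC(=O)NC1=O)c1ccc(-c2ccc3cccc(F)c3c2)[nH]c1=O` is next, with this change from compound 1: (2,5-dioxoimidazolidin-4-yl)methyl in place of 2,5-dioxoimidazolidin-4-yl on a saturated chain carbon bound to an aromatic carbon and a saturated chain carbon. In words, (2,5-dioxoimidazolidin-4-yl)methyl replaces 2,5-dioxoimidazolidin-4-yl on a saturated chain carbon bound to an aromatic carbon and a saturated chain carbon. Going by the values given here, no measured pair isolates this change, so the data give no size to carry over. In this assay, no shift beyond the scatter is expected, and the expectation is anchored on compound 1 at 0.145 h. The estimated 1.4-fold higher number from compound 1 to compound 3 (0.14 log units; within the scatter) is small. For compound 3, the expected half-life is 0.2 h, with an estimated range of 0.08 h to 0.6 h.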

Compound 3, half-life: 0.35 h
Estimate against measurement, compound 3: 1.8-fold (0.24 log units) below; measured number inside the range.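

In this assay, for the compounds shown here, the change to (2,5-dioxoimidazolidin-4-yl)methyl on a saturated chain carbon bound to an aromatic carbon and a saturated chain carbon gives a 2.4-fold higher number from compound 1 to compound 3 (0.38 log units; beyond the scatter), the first measured step at this place. The group that leaves and the group that enters carry the same ring, the same double bonds and the same donors and acceptors, so the step reads on the added methyl link alone, with the ring itself untouched. Nothing shown here bears on what lies behind this step.

One step cannot show whether a longer chain, such as an ethyl link to the same ring, would continue in the same direction. Also open, on these data alone, is how an amine or a carboxylic acid in place of the ring would behave at this place.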